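Changing the side chain of compound 3

This account rests on a few compounds, and the source may have more. Where it says the series, first, only, none or still open, it means among the compounds named here.

In an ADME assay for permeability, using PAMPA, with a stated time of 4 h, at pH 7.4 (a lower number here means that the compound crosses the layer more slowly, a higher number that the compound crosses the layer faster), compound 1 (`NCCCCN(C[C@H]1Cc2nccnc2CN1)[C@H]1CCCc2cccnc21`) gives 2 nm/s and compound 2 (`NCCCCN(C[C@@H]1Cc2nccnc2CN1)[C@H]1CCCc2cccnc21`) gives 2 nm/s. Compound 3 (`NC/C=C\CN(C[C@H]1Cc2ncccc2CN1)[C@H]1CCCc2cccnc21`) stands highest of the three at 68 nm/s, well beyond the scatter of both others. Compound 4 (`NC(=O)NC/C=C/CN(C[C@H]1Cc2ncccc2CN1)[C@H]1CCCc2cccnc21`) changes the chain of compound 3 (a group of 7 heavy atoms (4 carbon, 2 nitrogen, 1 oxygen; no ring) in place of a group of 4 heavy atoms (3 carbon, 1 nitrogen; no ring), on a saturated chain carbon bound to an amine nitrogen), on a saturated chain carbon bound to an amine nitrogen. Among the measured compounds shown here, the one measured step (no change at the digits printed from compound 1 to compound 2 (within the scatter)) rests on the fact that compounds 1 and 2 differ only in the configuration as drawn and does not involve this kind of change, so it offers little guidance on size. Only a loose expectation of a modest fall in this assay is possible, and the expected step is (a 2.7-fold lower number from compound 3 to compound 4 (0.43 log units; beyond the scatter)). The estimate for compound 4 is 25 nm/s, with an expected range from 5 nm/s to 120 nm/s and real uncertainty on both sides.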

Compound 4, apparent permeability: 2 nm/s
Compound 4: middle estimate off by 13-fold (1.10 log units), on the high side; the measured number lies below the stated range.
By their numbers in this assay, from the lowest: compounds 1, 2 and 4 (each within the scatter of the next); then compound 3.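

Swapping the 3-aminoprop-1-en-1-yl group for the group of 7 heavy atoms, on a saturated chain carbon bound to an amine nitrogen, gives in this assay a 34-fold lower number from compound 3 to compound 4 (1.53 log units; beyond the scatter). Among the compounds shown here, this is the first measured step showing that a change at this place can move the number well beyond the scatter. Nothing known about these compounds explains the size of this step.

The compounds shown leave open whether the fall follows the added carbonyl or simply the greater length. A longer chain ending in an amine, at the same place, would help separate the two.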